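Compound 4: trifluoromethyl added to compound 2

A few compounds are considered here, and "the series" means these few. Any claim that something is new, unique, unknown or untested is made for them only; others in the source may bear on it.

Within the data shown here, in an ADME assay on KB cells (Homo sapiens) for cytotoxicity, read by MTT assay, with a stated time of 72 h (on this read-out lower numbers stand for higher toxicity in this test and higher numbers for lower toxicity in this test), compound 2 `Clc1ccc(Nc2nc(-c3ccccn3)c(Cl)s2)nc1` gives 326000 nM, the highest of the three numbers so far. Compound 1 `Clc1ccc(Nc2nc(-c3ccccn3)cs2)nc1` gives 98600 nM, and compound 3 `COc1ccnc(-c2nc(Nc3ccc(Cl)cn3)sc2Cl)c1` gives 15000 nM. Compound 4 `FC(F)(F)c1ccc(-c2nc(Nc3ccc(Cl)cn3)sc2Cl)nc1` is not yet measured. Relative to compound 2, it carries trifluoromethyl in place of hydrogen on an aromatic carbon.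

Among the measured compounds shown here, two measured steps bear on this change, each replacing hydrogen on an aromatic carbon. Chloro gave a modest rise, a 3.3-fold higher number from compound 1 to compound 2 (0.52 log units; beyond the scatter). Methoxy gave a large fall, a 22-fold lower number from compound 2 to compound 3 (1.34 log units; beyond the scatter). These steps point in opposite directions and neither introduces trifluoromethyl, so the guidance is thin. The methoxy step starts from compound 2 itself and therefore carries more weight here, but its full size is not assumed to transfer. In this assay a moderate fall is expected, with the estimated step being a 4.1-fold lower number from compound 2 to compound 4 (0.61 log units; beyond the scatter). For compound 4 the estimate is 80000 nM, with an expected range of 20000 nM to 300000 nM.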

Compound 4, half-maximal cytotoxic concentration: > 400000 nM
Compound 4: only a limit was reported (the forecaster's own chance of this, stated with the estimate: 10%); middle value at least 5.0-fold (0.69 log units) away from the limit.
By their numbers in this assay, from the lowest: compound 3; then compound 1; then compound 2. At a limit, above all of these: compound 4.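

In this assay compound 4 gives > 400000 nM, which is a limit of the assay and not a number. Trifluoromethyl in place of hydrogen, on an aromatic carbon two atoms from the ring nitrogen and para to a large group, shows no sign of the fall seen with methoxy in a 22-fold lower number from compound 2 to compound 3 (1.34 log units; beyond the scatter), so a substituent on this ring does not by itself lower the number. The change can be read only as a floor, an at least 1.2-fold higher number from compound 2 to compound 4 (0.08 log units; that floor lies within the scatter), and its true size stays hidden: the limit of > 400000 nM in this assay, at which 1 of the 4 values shown sits.

From the compounds shown here alone, whether trifluoromethyl truly raises the number over hydrogen at this place remains open, since that floor lies within the scatter. Also open, going by these compounds, is how methoxy, an amine or a carboxylic acid would read at this same place, and so whether the outcome belongs to trifluoromethyl or to the place itself.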